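This account rests on a few compounds, and the source may have more. Where it says the series, first, only, none or still open, it means among the compounds named here.

Measured compounds in a functional assay on HL-60 cells (Homo sapiens) for cytotoxicity, read by MTT assay, with a stated time of 72 h; on this read-out higher numbers stand for weaker inhibition and lower numbers for stronger inhibition:

compound 1, `COc1ccc(Nc2nc3ccccc3nc2S(=O)(=O)c2ccc(C)cc2)cc1`, gives 2790 nM
compound 2, `COc1cc(Nc2nc3ccccc3nc2S(=O)(=O)c2ccc(C)cc2)cc(OC)c1`, gives 20 nM
compound 3, `COc1ccc(Nc2nc3ccccc3nc2S(=O)(=O)c2ccc(OC)cc2)cc1`, gives 1190 nM

Compound 4, `COc1ccc(S(=O)(=O)c2nc3ccccc3nc2Nc2cc(OC)cc(OC)c2)cc1`, has not yet been measured in this assay. It differs from compound 3 in one place: 3,5-dimethoxyphenyl in place of 4-methoxyphenyl on a nitrogen on an aromatic ring. The same change has already been made between two measured compounds, from compound 1 to compound 2: 3,5-dimethoxyphenyl in place of 4-methoxyphenyl on a nitrogen on an aromatic ring. That step was a 140-fold lower number from compound 1 to compound 2 (2.14 log units; beyond the scatter). Compound 3 and compound 4 rest on a core that differs from the core of compounds 1 and 2 in one place: methoxy in place of methyl on an aromatic carbon, a change that produced a 2.3-fold lower number from compound 1 to compound 3 (0.37 log units; beyond the scatter). The position at which the change is made is described in the same words in both pairs, so the change is the same.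

Among the compounds with values here, compound 4 is therefore expected to show a step of a 99-fold lower number from compound 3 to compound 4 (2.00 log units; beyond the scatter), of the same kind as the large step from compound 1 to compound 2, because compound 3 starts from 1190 nM and the only earlier example of this change, a 140-fold lower number from compound 1 to compound 2 (2.14 log units; beyond the scatter), was well beyond the scatter. Within the data shown here, since only one earlier instance exists and the core is not identical, the step may be somewhat smaller. The estimate for compound 4 in this assay is 12 nM, with a range from 3 nM to 60 nM.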

Compound 4, half-maximal inhibitory concentration: 1710 nM
For compound 4 the middle estimate is 140-fold (2.15 log units) below the measured one; measured number outside the range, above it.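

In this assay, the change to 3,5-dimethoxyphenyl in place of 4-methoxyphenyl on the nitrogen did not carry over from the core of compound 1 to the core of compound 3, since the new step is a 1.4-fold higher number from compound 3 to compound 4 (0.16 log units; within the scatter), and the two steps differ clearly: the same change on two cores in this assay, a 140-fold lower number (2.14 log units; beyond the scatter) from compound 1 to compound 2 and a 1.4-fold higher number (0.16 log units; within the scatter) from compound 3 to compound 4, 200-fold (2.30 log units) apart, beyond the scatter of two such steps

Seen from the other side, methoxy in place of methyl on an aromatic carbon gives an 86-fold higher number from compound 2 to compound 4 (1.93 log units; beyond the scatter), and this too departs from its earlier step: the same change on two cores in this assay, a 2.3-fold lower number (0.37 log units; beyond the scatter) from compound 1 to compound 3 and an 86-fold higher number (1.93 log units; beyond the scatter) from compound 2 to compound 4, 200-fold (2.30 log units) apart, beyond the scatter of two such steps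

So within these four compounds the two changes do not add up and the effect of each depends on the other, but a single set of four compounds does not show why, nor how far this holds elsewhere in the series.

The compounds shown leave open whether a chlorine or an ethyl group on that aromatic carbon would go with the low number of compound 2 or the high number of compound 4. They also leave open how an amine or a carboxylic acid in place of the methoxy groups on the 3,5-dimethoxyphenyl would behave on either core.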